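From Methoxy to Hydroxy: Compound 3 to Compound 4

A few compounds are considered here, and "the series" means these few. Any claim that something is new, unique, unknown or untested is made for them only; others in the source may bear on it.

Measured in an assay on isolated protein (thoracic aorta, strain Sprague-Dawley) for antagonist activity at Alpha-1D adrenergic receptor (Rattus norvegicus), with a stated time of 20 min; on this read-out higher numbers stand for weaker binding and lower numbers for tighter binding:
compound 1 `COc1ccccc1N1CCN(CCCNC(=O)c2ccc3[nH]ccc3c2)CC1` gives 11.8 nM
compound 2 `COc1ccccc1N1CCN(CCCNC(=O)Cc2c[nH]c3ccccc23)CC1` gives 5.25 nM
compound 3 `COc1ccc2[nH]c(C(=O)NCCCN3CCN(c4ccccc4OC)CC3)cc2c1` gives 58.9 nM

Compound 3 stands at the highest number of the three in this assay; compound 1 at 11.8 nM and compound 2 at 5.25 nM both sit clearly lower. Compound 4 `COc1ccccc1N1CCN(CCCNC(=O)c2cc3cc(O)ccc3[nH]2)CC1` differs from compound 3 by hydrogen in place of methyl on an oxygen on an aromatic ring. For the measured compounds named here, the only measured step, a 2.2-fold lower number from compound 1 to compound 2 (0.35 log units; beyond the scatter), changes the group on the carbonyl carbon and so says nothing about a change at this oxygen. Going by the values given here, with no step that bears on it, compound 4 is expected to stay within the scatter of compound 3, that is a 1.1-fold lower number from compound 3 to compound 4 (0.03 log units; within the scatter). The estimate for compound 4 in this assay is 55 nM, with a range from 20 nM to 160 nM.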

Compound 4, dissociation constant: 26.9 nM
Beside the measured number, compound 4's estimate is 2.0-fold (0.31 log units) above it, within the range that was stated.
By their numbers in this assay, from the lowest: compound 2; then compound 1; then compound 4; then compound 3.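

In this assay, for the compounds shown here, the group on this oxygen proves to matter, which the earlier compounds could not show: methoxy to hydroxy on the aromatic ring gives a 2.2-fold lower number from compound 3 to compound 4 (0.34 log units; beyond the scatter) and thus a tighter binder. The change does not carry the 5-hydroxy-1H-indol-2-yl compound past the earlier ones, as there is a 2.3-fold higher number from compound 1 to compound 4 (0.36 log units; beyond the scatter) and also a 5.1-fold higher number from compound 2 to compound 4 (0.71 log units; beyond the scatter) in the same read-out. Nothing available here accounts for the shift at this oxygen. From the compounds shown here alone, whether an ethoxy group or a longer chain on this oxygen, or an amine in place of the hydroxy, would move the number further remains open.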